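The compounds below may be only part of what the source reports. "The series", "measured", "known", "first", "only" and "open" are said of these compounds alone.

In a functional assay on K562 cells (Homo sapiens) for antiproliferative activity, read by MTT assay, with a stated time of 48 h (on this read-out lower numbers stand for stronger inhibition and higher numbers for weaker inhibition), compound 1 `CCn1c(N)c(-c2nc3ccccc3[nH]2)c2nc(C#N)c(C#N)nc21` is reported only as a limit, > 50000 nM. Among the measured compounds shown here, compound 2 `CN(C)CCCn1c(N)c(-c2nc3ccccc3[nH]2)c2nc(C#N)c(C#N)nc21` gives 1730 nM, the only actual number so far in this assay. Compound 3 `CN1CCN(CCCn2c(N)c(-c3nc4ccccc4[nH]3)c3nc(C#N)c(C#N)nc32)CC1` keeps the shared core but has 4-methylpiperazin-1-yl in place of dimethylamino on a saturated chain carbon, three bonds along the chain from an aromatic nitrogen. For the measured compounds named here, the one measured step bearing on this change, an at least 28-fold lower number from compound 1 to compound 2 (1.46 log units; beyond the scatter), is large. However, it rests on the limit in the limit of > 50000 nM in this assay, at which 1 of the 2 values shown sits, and concerns adding the (dimethylamino)methyl group, not exchanging its amine, so it gives no direct size for the present change. The expectation therefore stays anchored on compound 2 at 1730 nM, with no step beyond the scatter expected in this assay. The estimate means a 1.0-fold higher number from compound 2 to compound 3 (0.02 log units; within the scatter). For compound 3 the expected value is 1800 nM, with an estimated range from 600 nM to 6000 nM.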

Compound 3, half-maximal inhibitory concentration: 1260 nM
Beside the measured number, compound 3's estimate is 1.4-fold (0.15 log units) above it; low and high end bracket the measured number.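

In this assay, 4-methylpiperazin-1-yl in place of dimethylamino gives a 1.4-fold lower number from compound 2 to compound 3 (0.14 log units; within the scatter), so at this place, on a saturated chain carbon three bonds along the chain from an aromatic nitrogen, the larger group with its six-membered non-aromatic ring leaves the number within the scatter. The advantage over compound 1 is thus not tied to dimethylamino alone, as the 3-(4-methylpiperazin-1-yl)propyl chain also gives an at least 39-fold lower number from compound 1 to compound 3 (1.59 log units; beyond the scatter). That step starts from a limit for compound 1 and not from a number: the limit of > 50000 nM in this assay, at which 1 of the 3 values shown sits.

The compounds shown leave open whether morpholine or a hydroxyl group in the same place would keep the number at this level. They also leave open whether a longer chain carrying dimethylamino would shift it beyond the scatter.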